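The source may report more compounds than this note shows. Statements on the series, on what has been measured and on what is new or still open speak of the compounds shown alone.

Working notes on the series. Three compounds share one core and differ only in the group on a carbonyl carbon. Compound 1 `CC(C)(C)c1ccc(C(=O)N2CCC3(CC2)C(=O)N(CC(=O)NCNS(C)(=O)=O)CN3c2ccccc2)cc1` gives 3200 nM in an assay on HEK293 cells for displacement of a labelled ligand from NPC1-like intracellular cholesterol transporter 1 (Homo sapiens); on this read-out lower numbers stand for stronger inhibition and higher numbers for weaker inhibition. Compound 2 `CC(C)(C)c1ccc(C(=O)N2CCC3(CC2)C(=O)N(CC(=O)N2CCCC(CO)C2)CN3c2ccccc2)cc1` gives 8200 nM. For the measured compounds named here, compound 3 `CCOC(=O)C1CCN(C(=O)CN2CN(c3ccccc3)C3(CCN(C(=O)c4ccc(C(C)(C)C)cc4)CC3)C2=O)CC1` gives 3100 nM, the lowest of the three numbers, yet its gap to compound 1 is within the scatter, and only the step of a 2.6-fold lower number from compound 2 to compound 3 (0.42 log units; beyond the scatter) is beyond it. The next compound, compound 4 `CC(C)(C)c1ccc(C(=O)N2CCC3(CC2)C(=O)N(CC(=O)NCCCCNS(C)(=O)=O)CN3c2ccccc2)cc1`, changes the same carbonyl carbon: (4-(methanesulfonamido)butyl)amino in place of 4-(ethoxycarbonyl)piperidin-1-yl on a carbonyl carbon. The step that bears most on this is a 1.0-fold lower number from compound 1 to compound 3 (0.01 log units; within the scatter), since compound 1 already carries a methanesulfonamide-bearing chain in this place and its number was within the scatter of compound 3. Going by the values given here, compound 4 carries a longer chain of that kind, for which no measured step exists. The step of a 2.6-fold lower number from compound 2 to compound 3 (0.42 log units; beyond the scatter) shows that changes here can move the number modestly. On this basis compound 4 is expected to land near compound 3, with the step of a 1.1-fold higher number from compound 3 to compound 4 (0.05 log units; within the scatter) estimated within the scatter. The estimate for compound 4 in this assay is 3500 nM, with a range from 1500 nM to 8500 nM.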

Compound 4, half-maximal inhibitory concentration: 4500 nM
Compound 4: middle estimate off by 1.3-fold (0.11 log units), on the low side; measured number inside the range.
By their numbers in this assay, from the lowest: compounds 3, 1, 4 and 2 (each within the scatter of the next, the first and the last beyond it).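

In this assay, a ring-free chain is tolerated on this carbonyl carbon: (4-(methanesulfonamido)butyl)amino in place of 4-(ethoxycarbonyl)piperidin-1-yl, with hydrogen-bond donors going from 0 to 2, gives a 1.5-fold higher number from compound 3 to compound 4 (0.16 log units; within the scatter). Extending the chain that carries the methanesulfonamide, with 3-(methanesulfonamido)propyl in place of methanesulfonamido, also stays inside the scatter, with a 1.4-fold higher number from compound 1 to compound 4 (0.15 log units; within the scatter). The third new step, a 1.8-fold lower number from compound 2 to compound 4 (0.26 log units; within the scatter), places compound 4 within the scatter of all three earlier compounds, so it does not add a separation beyond the one in a 2.6-fold lower number from compound 2 to compound 3 (0.42 log units; beyond the scatter).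

No supporting data bear on the origin of these numbers. Open, from the compounds shown here alone, is whether an amine or a carboxylic acid in place of methanesulfonamido on the butyl chain, or a longer chain, would move the number beyond the scatter of compound 3.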